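Fluoro to methyl on the chain carbon of compound 2

This account rests on a few compounds, and the source may have more. Where it says the series, first, only, none or still open, it means among the compounds named here.

Compound 1 `COC(Cc1ccc(OCc2cccc(-c3c(C)cccc3C)c2)nc1)C(=O)O` sits at the limit of > 10000 nM in this assay, at which 1 of the 2 values shown sits, in a functional assay on CHO cells for agonist activity at Free fatty acid receptor 1 (Rattus norvegicus), read by calcium flux (a higher number here means that more compound is needed for the effect, a lower number that less compound is needed), reported as > 10000 nM. Among the compounds with values here, compound 2 `Cc1cccc(C)c1-c1cccc(COc2ccc(C(F)CC(=O)O)cn2)c1` gives 96 nM, the only number in this assay so far. Within the data shown here, the single measured step, an at least 100-fold lower number from compound 1 to compound 2 (2.01 log units; beyond the scatter), concerns a different part of the chain. Compound 3 `Cc1cccc(C)c1-c1cccc(COc2ccc(C(C)CC(=O)O)cn2)c1` carries methyl in place of fluoro on a saturated chain carbon bound to an aromatic carbon and a saturated chain carbon. Among the measured compounds shown here, no measured step involves this exchange, so the step from compound 1 to compound 2 offers no direct guide. The change is expected to stay near the scatter, a 1.6-fold higher number from compound 2 to compound 3 (0.19 log units; within the scatter). Compound 3 is therefore estimated at 150 nM, within 40 nM to 600 nM.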

Compound 3, half-maximal effective concentration: 320 nM
The estimate for compound 3 lay 2.1-fold (0.33 log units) below the measured number; the range from low to high includes it.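

Methyl in place of fluoro on a saturated chain carbon bound to an aromatic carbon and a saturated chain carbon is not a neutral exchange in this assay: it gives a 3.3-fold higher number from compound 2 to compound 3 (0.52 log units; beyond the scatter). The 1-(carboxymethyl)ethyl group still stands well clear of the 2-carboxy-2-methoxyethyl group, with an at least 31-fold lower number from compound 1 to compound 3 (1.49 log units; beyond the scatter). Compound 1 stands at a limit, not at a number: the limit of > 10000 nM in this assay, at which 1 of the 3 values shown sits.

As far as these compounds go, whether a hydroxyl or a plain hydrogen on that carbon would fall nearer fluoro or methyl stays open, as does the outcome with an ethyl group there.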